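This account rests on a few compounds, and the source may have more. Where it says the series, first, only, none or still open, it means among the compounds named here.

Working notes on the series. Three analogues share one core and differ only in the aryl group attached through the oxygen on the saturated carbon. Compound 1 `CC(C)[C@H](NC(=O)COc1cccc2ccccc12)C(=O)N[C@@H](CC(=O)O)C(=O)COc1ccc(Oc2ccccc2)cc1` gives 19000 nM in a functional assay with Homo sapiens as the target; a lower number here means a stronger inhibitor, a higher number a weaker inhibitor. Compound 2 `CC(C)[C@H](NC(=O)COc1cccc2ccccc12)C(=O)N[C@@H](CC(=O)O)C(=O)COc1ccc(Oc2ccc(C(F)(F)F)cc2)cc1` gives 24900 nM in this assay. Compound 3 `CC(C)[C@H](NC(=O)COc1cccc2ccccc12)C(=O)N[C@@H](CC(=O)O)C(=O)COc1ccc(F)cc1` gives 14300 nM in this assay. Compound 3 carries the lowest of the three numbers, yet the steps onto it are a 1.3-fold lower number from compound 1 to compound 3 (0.12 log units; within the scatter) and a 1.7-fold lower number from compound 2 to compound 3 (0.24 log units; within the scatter), so the three compounds cannot be separated.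

Compound 4 `CC(C)[C@H](NC(=O)COc1cccc2ccccc12)C(=O)N[C@@H](CC(=O)O)C(=O)COc1ccc([N+](=O)[O-])cc1F` is the next member: 2-fluoro-4-nitrophenyl in place of 4-fluorophenyl on an oxygen on a saturated carbon.

Among the measured compounds shown here, the steps that bear on this change are all exchanges of the same aryl group. Replacing phenoxy by fluoro gave a 1.3-fold lower number from compound 1 to compound 3 (0.12 log units; within the scatter); replacing 4-(trifluoromethyl)phenoxy by fluoro gave a 1.7-fold lower number from compound 2 to compound 3 (0.24 log units; within the scatter); adding trifluoromethyl to the outer ring gave a 1.3-fold higher number from compound 1 to compound 2 (0.12 log units; within the scatter). None moved this assay beyond the scatter, so this part of the molecule tolerates substitution without a measurable shift. Going from 4-fluorophenoxy to 2-fluoro-4-nitrophenoxy is therefore expected to give a 1.0-fold higher number from compound 3 to compound 4 (0.02 log units; within the scatter), no step beyond the scatter. Compound 4 is estimated at 15000 nM in this assay, with an expected range from 6000 nM to 40000 nM.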

Compound 4, half-maximal inhibitory concentration: 15800 nM
Estimate against measurement, compound 4: 1.1-fold (0.02 log units) below; measured number inside the range.
By their numbers in this assay, from the lowest: compounds 3, 4, 1 and 2 (each within the scatter of the next).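

Among the compounds shown here, exchanging 4-fluorophenyl for 2-fluoro-4-nitrophenyl on the oxygen gave a 1.1-fold higher number from compound 3 to compound 4 (0.04 log units; within the scatter) in this assay, so the tolerance at this position now covers a ring bearing both a fluoro and a nitro group, a substitution that none of the earlier compounds carried. This change also moves from 0 to 2 hydrogen-bond acceptors in the exchanged group and adds heavy atoms, yet the result still cannot be separated from compound 3, and no listed step at this position lies beyond the scatter. Nothing measured here accounts for this flat response. What a saturated alkyl chain in place of the aromatic ring, or an amine or a carboxylic acid on that ring, would do in this assay stays open, since every compound shown keeps an aryl group on this oxygen. The shared core is also constant across all four compounds, so they give no reading of how any other part of the molecule bears on these numbers.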